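Working notes: from compound 1 to compound 3 in cytotoxicity

The source may hold more compounds than are shown below. What is called first, only, known or untested is meant among the compounds shown, and "the series" means these compounds.

Compound 1 `CCc1ccc(C(=O)/C=C/c2ccc3c(c2)B(O)OC3)cc1` — > 10 ug/mL
Compound 2 `O=C(/C=C/c1ccc2c(c1)B(O)OC2)c1ccc(Cl)c(Cl)c1` — > 10 ug/mL

In an ADME assay on L929 cells (Mus musculus) for cytotoxicity, read by resazurin assay, with a stated time of 72 h (a lower number here means a stronger inhibitor, a higher number a weaker inhibitor), compound 1 gives > 10 ug/mL, which is a limit of the assay rather than a number. Compound 2 likewise gives > 10 ug/mL in this assay, again a limit. Among the compounds with values here, compound 1 thus stands at the limit of > 10 ug/mL in this assay, at which 2 of the 2 values shown sit, and no measured step exists to judge it by. Compound 3 `COc1ccc(C(=O)/C=C/c2ccc3c(c2)B(O)OC3)cc1` differs from compound 1 by methoxy in place of ethyl on an aromatic carbon. With both known values sitting at the limit, no step beyond the scatter is expected in this assay, in either direction. Compound 3 is expected to give about 15 ug/mL, in the range 8 ug/mL to 40 ug/mL, most likely reported again only as a limit. The expected step is a step that the limit leaves unreadable from compound 1 to compound 3.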

Compound 3, half-maximal inhibitory concentration: > 10 ug/mL
Compound 3 ended at the assay's limit (the forecaster's own chance of this, stated with the estimate: 85%); the middle value does not contradict the limit.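

No step can be read between compound 1 and compound 3, since both values are limits of the assay: the limit of > 10 ug/mL in this assay, at which 3 of the 3 values shown sit.
The compounds shown leave open whether methoxy in place of ethyl on an aromatic carbon alters cytotoxicity at all.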